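Replacing the hydroxy of compound 1 with an alkylamino group

The source may hold more compounds than are shown below. What is called first, only, known or untested is meant among the compounds shown, and "the series" means these compounds.

For the measured compounds named here, compound 1 `O=C(O)CCC(=O)OCCCCCCSc1ccc([N+](=O)[O-])c2nonc12` is the acid of the series; in an assay on isolated protein for inhibition of glutathione S-transferase Mu 2 (Homo sapiens), with a stated time of 10 min (on this read-out higher numbers stand for weaker inhibition and lower numbers for stronger inhibition), compound 1 gives 160 nM, the lowest of the three numbers so far. Two amides are measured. Compound 2 `O=C(CCC(=O)OCCCCCCSc1ccc([N+](=O)[O-])c2nonc12)Nc1ccc(F)cc1` gives 320 nM and compound 3 `COc1ccc(NC(=O)CCC(=O)OCCCCCCSc2ccc([N+](=O)[O-])c3nonc23)cc1OC` gives 360 nM. The step of a 2.0-fold higher number from compound 1 to compound 2 (0.30 log units; within the scatter) and the step of a 2.3-fold higher number from compound 1 to compound 3 (0.35 log units; beyond the scatter) both point the same way, the second only modestly beyond the scatter; between the two amides, a 1.1-fold higher number from compound 2 to compound 3 (0.05 log units; within the scatter).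

Compound 4 `CN(C)CCCNC(=O)CCC(=O)OCCCCCCSc1ccc([N+](=O)[O-])c2nonc12` is not yet measured. Relative to compound 1 the change is (3-(dimethylamino)propyl)amino in place of hydroxy on a carbonyl carbon. Going by the values given here, both measured steps from compound 1 replaced the hydroxy on the carbonyl carbon with an amino group bearing a ring; no measured step covers a (3-(dimethylamino)propyl)amino group or any chain of this kind, so the two anilide steps are the only guide. Because a 2.0-fold higher number from compound 1 to compound 2 (0.30 log units; within the scatter) and a 2.3-fold higher number from compound 1 to compound 3 (0.35 log units; beyond the scatter) were both small and upward, compound 4 is expected to show a step of similar size, a 1.9-fold higher number from compound 1 to compound 4 (0.27 log units; within the scatter), which may still fall within the scatter. The estimate for compound 4 is 300 nM, expected between 130 nM and 700 nM.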

Compound 4, half-maximal inhibitory concentration: 90 nM
The estimate for compound 4 lay 3.3-fold (0.52 log units) above the measured number; measured number below the stated range.
By their numbers in this assay, from the lowest: compounds 4, 1, 2 and 3 (each within the scatter of the next, the first and the last beyond it).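

The open-chain (3-(dimethylamino)propyl)amino group on the carbonyl carbon stays level with the hydroxy within the scatter (a 1.8-fold lower number from compound 1 to compound 4 (0.25 log units; within the scatter)), so replacing the hydroxy does not by itself raise the number, as the two ring-bearing amides alone might have suggested. The group on the amide nitrogen does matter, a point the two anilides could not show, since they sit within the scatter of each other: a 3.6-fold lower number from compound 2 to compound 4 (0.55 log units; beyond the scatter) and a 4.0-fold lower number from compound 3 to compound 4 (0.60 log units; beyond the scatter), both beyond the scatter though modest. Nothing available explains these steps.

The compounds shown leave open whether the terminal dimethylamino group or the saturated chain carries the difference from the anilides. A plain butylamino or 3-hydroxypropylamino group would separate the two, and a 2-(dimethylamino)ethylamino or longer 4-(dimethylamino)butylamino group would test the chain length.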